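The compounds below may be only part of what the source reports. "The series", "measured", "known", "first", "only" and "open" are said of these compounds alone.

Measured compounds in an ADME assay on HEK293 cells (Homo sapiens) for cytotoxicity, read by ATP content, with a stated time of 6 h; on this read-out lower numbers stand for higher toxicity in this test and higher numbers for lower toxicity in this test:
- compound 1 `CCCCNc1nc(N)nc2ccn(Cc3ccccn3)c12`, for which compound 1 gives > 24000 nM, a limit of the assay and not a number
- compound 2 `CCCCNc1nc(N)nc2ccn(Cc3cccc(C)n3)c12`, for which compound 2 gives > 24000 nM, likewise a limit
- compound 3 `CCCCNc1nc(N)nc2ccn(Cc3ncc(C)c(OC)c3C)c12`, for which compound 3 gives > 24000 nM, likewise a limit

Compound 1 therefore stands at the top limit of this assay, and the two further values shown sit at the same limit, as the evidence states: the limit of > 24000 nM in this assay, at which 3 of the 3 values shown sit. The account follows the step from compound 1 to compound 4 `CC(C)c1cc(CNc2nc(N)nc3ccn(Cc4ccccn4)c23)no1`. The change is 5-isopropyl-1,2-oxazol-3-yl in place of propyl on a saturated chain carbon bound to a nitrogen on an aromatic ring. Within the data shown here, only one measured step exists among the shared core's neighbours, a step that the two limits leave unreadable from compound 1 to compound 2, and its size cannot be read because both of its values are limits; moreover it concerns methyl in place of hydrogen on an aromatic carbon, not a change at a saturated chain carbon bound to a nitrogen on an aromatic ring, so it bears on the present change only loosely. Among the measured compounds shown here, no measured step therefore tells how large a change to expect in this assay, in either direction, and the three limits give no more than that the measured compounds show low toxicity in this test. The expectation for compound 4 is that it, too, most likely sits at or beyond the limit, a step that the limit leaves unreadable from compound 1 to compound 4 being expected. Compound 4 is estimated at 30000 nM, with a range from 10000 nM to 100000 nM.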

Compound 4, half-maximal cytotoxic concentration: > 24000 nM
Compound 4: a limit, no number; the forecaster's own chance of this, stated with the estimate: 75%; the middle value lies beyond the limit too.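

In this assay compound 4 and compound 1 both give a limit of the assay and not a number, so no new step can be read between them: the limit of > 24000 nM in this assay, at which 4 of the 4 values shown sit.

The compounds shown leave open how far each lies beyond that limit, and whether any change to the shared core would give a readable number in this assay.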